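A trifluoromethoxy group added to compound 3

A few compounds are considered here, and "the series" means these few. Any claim that something is new, unique, unknown or untested is made for them only; others in the source may bear on it.

Values in a functional assay on MDA-MB-231 cells (Homo sapiens) for antiproliferative activity, read by MTT assay, with a stated time of 48 h; a higher number here means a weaker inhibitor, a lower number a stronger inhibitor:
Compound 1 `CN1CCN(c2ccc(-c3cc4c(N5CCN(S(=O)(=O)/C=C/c6ccccc6)CC5)ncnc4s3)cc2)CC1`: 5900 nM
Compound 2 `CN1CCN(c2ccc(-c3cc4c(N5CCN(S(=O)(=O)N6CCCCC6)CC5)ncnc4s3)cc2)CC1`: 8130 nM
Compound 3 `CN1CCN(c2ccc(-c3cc4c(N5CCN(C(=O)Nc6ccccc6)CC5)ncnc4s3)cc2)CC1`: 7590 nM

The three values lie close together, and compound 3 cannot be told apart from the other two. The steps to it are a 1.3-fold higher number from compound 1 to compound 3 (0.11 log units; within the scatter) and a 1.1-fold lower number from compound 2 to compound 3 (0.03 log units; within the scatter). Compound 4 `CN1CCN(c2ccc(-c3cc4c(N5CCN(C(=O)Nc6ccc(OC(F)(F)F)cc6)CC5)ncnc4s3)cc2)CC1` carries one change: trifluoromethoxy in place of hydrogen on an aromatic carbon. Within the data shown here, no measured step tests this change directly. The closest evidence comes from swapping whole groups on an amine nitrogen in a ring, and even a 1.4-fold higher number from compound 1 to compound 2 (0.14 log units; within the scatter) stayed small. A step beyond the scatter is therefore not expected, and the data favour no direction. The expected step is a 1.3-fold lower number from compound 3 to compound 4 (0.10 log units; within the scatter). Compound 4 is estimated at 6000 nM, within an expected range of 2200 nM to 12000 nM.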

Compound 4, half-maximal inhibitory concentration: 4600 nM
Compound 4: middle estimate off by 1.3-fold (0.12 log units), on the high side; the measured number falls inside the stated range.
By their numbers in this assay, from the lowest: compounds 4, 1, 3 and 2 (each within the scatter of the next).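

Compound 1, compound 2 and compound 3 differ in whole groups on an amine nitrogen in a ring, whereas compound 4 tests a change on the phenyl ring of the phenylcarbamoyl group, para to a large group. In this assay, trifluoromethoxy in place of hydrogen there gives a 1.7-fold lower number from compound 3 to compound 4 (0.22 log units; within the scatter), so this position accepts the larger group without a step that stands out from the scatter. Nothing measured here offers an explanation for this step. From the compounds shown here alone, whether an amine or a carboxylic acid at this position would produce a step beyond the scatter remains open.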